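Notes on the chain change from compound 2 to compound 4

The source may report more compounds than this note shows. Statements on the series, on what has been measured and on what is new or still open speak of the compounds shown alone.

Compound 2 `CSc1nc(NCCCCc2ccccc2)c2ccccc2n1` gives 64000 nM in a functional assay on MCF7 cells (Homo sapiens) for cytotoxicity, read by MTT assay, with a stated time of 72 h (a higher number here means a weaker inhibitor of growth, a lower number a stronger inhibitor of growth), the higher of the two numbers recorded so far. Compound 1 `[SeH]c1nc([SeH])c2ccccc2n1` gives 22900 nM in this assay. Compound 3 `Nc1nc([SeH])nc2ccccc12` reaches only the limit > 100000 nM in this assay, a limit and not a number. Among the measured compounds shown here, the one measured single-point step, an at least 4.3-fold higher number from compound 1 to compound 3 (0.64 log units; beyond the scatter), sits on the aromatic core and ends at the limit (the limit of > 100000 nM in this assay, at which 1 of the 3 values shown sits); it does not involve the chain. Compound 4 `CSc1nc(NCCCCCO)c2ccccc2n1` differs from compound 2 by hydroxymethyl in place of phenyl on a saturated chain carbon, four bonds along the chain from a nitrogen on an aromatic ring. For the measured compounds named here, no measured step covers this chain change, so the expectation rests on the structural change alone. The estimated step of a 1.6-fold higher number from compound 2 to compound 4 (0.19 log units; within the scatter) is expected to be small, towards a somewhat higher number. Compound 4 is therefore estimated at 100000 nM, with a range from 30000 nM to 300000 nM, and a fair chance that only a limit is reported.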

Compound 4, concentration for total growth inhibition: > 100000 nM
Compound 4 ended at the assay's limit (the forecaster's own chance of this, stated with the estimate: 45%); the middle value lies on the limit itself.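

The chain position now has its first measured step, readable only as a floor: in this assay hydroxymethyl in place of phenyl gives an at least 1.5-fold higher number from compound 2 to compound 4 (0.19 log units; that floor lies within the scatter) and no upper bound. Compound 4 gives > 100000 nM as a limit and not a number, so the full size of this change cannot be read. This chain change, like the core change before it, ends at the limit: the limit of > 100000 nM in this assay, at which 2 of the 4 values shown sit.

As far as these compounds go, an amine or a carboxylic acid in place of the hydroxyl, or a longer chain still carrying phenyl, remains open. Whether any of these would return a number below the limit is also unresolved.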